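This account rests on a few compounds, and the source may have more. Where it says the series, first, only, none or still open, it means among the compounds named here.

Measured so far in a functional assay on MCF7 cells (Homo sapiens) for inhibition, read by MTT assay, with a stated time of 48 h, tested at 30 ug/mL; a higher number here means more inhibition of growth at the concentration tested, a lower number less inhibition of growth:
compound 1, `COc1cc2c(c(OC)c1)OCN(c1ccc3oc(-c4ccccc4)cc(=O)c3c1)C2`: 79%
compound 2, `O=c1cc(-c2ccccc2)oc2cc(N3COc4ccccc4C3)ccc12`: 12.7%

For the measured compounds named here, only two compounds carry numbers. In this assay compound 1 gives 79%, and compound 2 gives 12.7%. Compound 2 thus stands lowest of the two; its nearest neighbour is compound 1, whose number is higher by a gap beyond the scatter. Going by the values given here, no single-point step between these two is defined, so the pair shows no more than its two values.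

Compound 3, `O=c1cc(-c2ccccc2)oc2cc(N3COc4c(Br)cccc4C3)ccc12`, is not yet measured. It differs from compound 2 by bromo in place of hydrogen on an aromatic carbon: one bromine enters, no ring, no donor or acceptor, no charge. Among the compounds with values here, no comparable step exists, so the size of the change cannot be read from measured numbers. The step from compound 2 to compound 3 in this assay is expected to be small, a number 7.3 percentage points higher from compound 2 to compound 3 (within the scatter), upward if anything and probably not beyond the scatter. Compound 3 is estimated at 20%, with a range from 5% to 45%.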

Compound 3, percent growth inhibition at one concentration: 7.89%
Compound 3: the middle estimate sits 12.1 percentage points above what was measured, within the range that was stated.
By their numbers in this assay, from the lowest: compounds 3 and 2 (each within the scatter of the next); then compound 1.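

In this assay, for the compounds shown here, bromo in place of hydrogen on an aromatic carbon, ortho to a fused ring and meta to a fused ring, gives a number 4.8 percentage points lower from compound 2 to compound 3 (within the scatter) and is the only single-place step so far. At this position, the entry of one bromine leaves compound 2 and compound 3 indistinguishable in this read-out, so this change on this core gives no sign of an effect on growth inhibition. No supporting measurement bears on why the step has this size.

As far as these compounds go, whether an amine or a carboxylic acid at the same aromatic carbon would also stay within the scatter remains open. Also open, from the compounds shown here alone, is whether bromo at this position would give a similar step on the core of compound 1, which gives 79% in this assay and carries more room for a fall.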